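Replacing the ethylpiperazine of compound 1 with an open chain

The source may report more compounds than this note shows. Statements on the series, on what has been measured and on what is new or still open speak of the compounds shown alone.

Measured in a functional assay on MV4-11 cells (Homo sapiens) for inhibition, read by luminescence, with a stated time of 72 h; on this read-out lower numbers stand for stronger inhibition and higher numbers for weaker inhibition:
- compound 1 `CCN1CCN(Cc2cc(Nc3ncc(F)c(-c4ccc(F)cc4OC)n3)cc3c2OCC(=O)N3CC)CC1`: 142 nM
- compound 2 `CCN1C(=O)COc2c(CN3CCN(C(C)=O)CC3)cc(Nc3ncc(F)c(-c4ccc(F)cc4OC)n3)cc21`: 17 nM
- compound 3 `CCN1C(=O)COc2c(CN3CCC(N(C)C)C3)cc(Nc3ncc(F)c(-c4ccc(F)cc4OC)n3)cc21`: 124 nM

Compound 1 holds the highest of these three numbers, though only compound 2 is separated from it by more than the scatter (an 8.4-fold lower number from compound 1 to compound 2 (0.92 log units; beyond the scatter)). Compound 3 cannot be told apart from it (a 1.1-fold lower number from compound 1 to compound 3 (0.06 log units; within the scatter)).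

The next compound is compound 4 `CCN1C(=O)COc2c(CN(C)CCN(C)C)cc(Nc3ncc(F)c(-c4ccc(F)cc4OC)n3)cc21`, which has not yet been measured. It differs from compound 1 in one place ((2-(dimethylamino)ethyl)(methyl)amino in place of 4-ethylpiperazin-1-yl on a saturated chain carbon bound to an aromatic carbon).

The closest evidence is the change from compound 1 to compound 3, which also replaces the 4-ethylpiperazin-1-yl at this place and brings a dimethylamino group (a 1.1-fold lower number from compound 1 to compound 3 (0.06 log units; within the scatter)). The larger steps both involve the acetyl group of compound 2 (an 8.4-fold lower number from compound 1 to compound 2 (0.92 log units; beyond the scatter) and a 7.3-fold higher number from compound 2 to compound 3 (0.86 log units; beyond the scatter)), and compound 4 has no acetyl group. Among the compounds with values here, no measured compound has a group without a ring at this place, so the comparison remains indirect.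

The expected outcome in this assay is therefore no step beyond the scatter (a 1.2-fold lower number from compound 1 to compound 4 (0.07 log units; within the scatter)). The estimated value for compound 4 is 120 nM, with an expected range from 45 nM to 320 nM.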

Compound 4, half-maximal inhibitory concentration: 143 nM
Beside the measured number, compound 4's estimate is 1.2-fold (0.08 log units) below it, and the stated range covers the measured number.
By their numbers in this assay, from the lowest: compound 2; then compounds 3, 1 and 4 (each within the scatter of the next).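

In this assay, the ring of the 4-ethylpiperazin-1-yl group proves unnecessary for holding the level of compound 1, since the ring-free (2-(dimethylamino)ethyl)(methyl)amino group on the same saturated chain carbon changes nothing beyond the scatter (a 1.0-fold higher number from compound 1 to compound 4 (0.00 log units; within the scatter)). The open chain also cannot be told apart from the 3-(dimethylamino)pyrrolidin-1-yl group (a 1.2-fold higher number from compound 3 to compound 4 (0.06 log units; within the scatter)), so the three groups of compounds 1, 3 and 4, with their differing ring content, read alike, while compound 2 with its 4-acetylpiperazin-1-yl group stands apart from the open chain as well (an 8.4-fold higher number from compound 2 to compound 4 (0.92 log units; beyond the scatter)). Nothing measured here explains why these groups read alike or why compound 2 differs.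

The compounds shown leave open whether an open chain ending in an acetyl amide would reach the level of compound 2, which would show whether the acetyl group needs the piperazine ring around it. They also do not tell how a longer chain carrying the dimethylamino group, or a morpholine ring, would read on this saturated chain carbon in this assay.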